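From hydroxymethyl to 2-cyanoethenyl at the assay limit

A few compounds are considered here, and "the series" means these few. Any claim that something is new, unique, unknown or untested is made for them only; others in the source may bear on it.

In a functional assay on SEM cells (Homo sapiens) for cytotoxicity, with a stated time of 72 h (a higher number here means that more compound is needed for the effect, a lower number that less compound is needed), compound 1 `C=C[C@@](C)(/C=C/c1ccc(O)cc1)CC/C=C(\C)CO` reads > 36600 nM and that is a limit, not a number. Compound 2 `C=C[C@@](C)(/C=C/c1ccc(O)c(CO)c1)CCC=C(C)C` reads > 36600 nM and that too is only a limit. Compound 2 therefore has no measured potency to compare, and the two results together rest on the limit of > 36600 nM in this assay, at which 2 of the 2 values shown sit, without giving a number for any step.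

Among the compounds with values here, compound 3 `C=C[C@@](C)(/C=C/c1ccc(O)c(/C=C/C#N)c1)CCC=C(C)C` keeps the rest of compound 2 but carries 2-cyanoethenyl in place of hydroxymethyl on an aromatic carbon, ortho to a hydroxy group 2-cyanoethenyl in place of hydroxymethyl on an aromatic carbon as the only change. Within the data shown here, no measured step shows what such a replacement does in this assay so the expectation is tentative. A modest shift toward less compound being needed is expected, although the result may remain at the limit. The expected step is an at least 1.8-fold lower number from compound 2 to compound 3 (0.26 log units; that floor lies within the scatter) on this estimate. For compound 3 the estimated value is 20000 nM with an expected range from 6000 nM to 36600 nM and a real chance that it stays at the limit again.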

Compound 3, half-maximal effective concentration: > 36600 nM
Compound 3: no number, only a limit; the forecaster's own chance of this, stated with the estimate: 50%; middle value at least 1.8-fold (0.26 log units) away from the limit.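

Compound 2 and compound 3 give no readable step in this assay, because both results are only limits: the limit of > 36600 nM in this assay, at which 3 of the 3 values shown sit.

The compounds shown leave open what potency any of them has in this assay, and whether 2-cyanoethenyl in place of hydroxymethyl changes it at all.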